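The source may report more compounds than this note shows. Statements on the series, on what has been measured and on what is new or still open speak of the compounds shown alone.

Compound 1 `Cc1ccc(NC(=O)N[C@H](C)c2ccccc2)cc1` and compound 2 `Cc1ccc(NC(=O)N[C@@H](C)c2ccccc2)cc1` are built from the same atoms and bonds. In an ADME assay on the whole organism with Oryza sativa as the target, tested at 10 uM (a higher number here means a weaker effect of the compound at the concentration tested, a lower number a stronger effect), compound 1 gives 64%, the lower of the two numbers, while compound 2 gives 100%. That gap is a number 36 percentage points higher from compound 1 to compound 2 (beyond the scatter), and it rests only on (the fact that compounds 1 and 2 differ only in the configuration as drawn). Compound 3 `CCc1ccc(NC(=O)N[C@H](C)c2ccccc2)cc1` differs from compound 1 by methyl in place of hydrogen on a saturated chain carbon bound to an aromatic carbon. Going by the values given here, no measured step touches a change of this kind, since the only one swaps configuration. A step of about no change at the digits printed from compound 1 to compound 3 (within the scatter) is expected, staying within scatter. Compound 3 is therefore estimated at 64%, between 45% and 85%.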

Compound 3, a percentage reported as activity, at one concentration (the size of the read-out at that concentration, not a potency): 44%
Compound 3: middle estimate off by 20 percentage points, on the high side; the whole stated range lies above it.
By their numbers in this assay, from the lowest: compound 3; then compound 1; then compound 2.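

In this assay, the position on a saturated chain carbon bound to an aromatic carbon proves sensitive to a small change: methyl in place of hydrogen, which turns methyl into ethyl, gives a number 20 percentage points lower from compound 1 to compound 3 (beyond the scatter) and so a stronger effect. This shows that the read-out responds to the size of this group as well as to configuration. Nothing shown here explains this step. As far as these compounds go, whether a propyl chain would extend the trend remains open, as does what an amine would do here.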